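Growth inhibition notes: compound 3 to compound 4

The compounds below may be only part of what the source reports. "The series", "measured", "known", "first", "only" and "open" are said of these compounds alone.

In a functional assay on MV4-11 cells (Homo sapiens) for inhibition, read by resazurin assay, with a stated time of 72 h (a higher number here means a weaker inhibitor of growth, a lower number a stronger inhibitor of growth), compound 1 `O=C1NCCC12CCN(c1c(Cl)cncc1-c1ccoc1)CC2` gives 750 nM, compound 2 `O=C1NCCC12CCN(c1c(Cl)cncc1-c1cc[nH]c1)CC2` gives 1050 nM and compound 3 `O=C1NCCC12CCN(c1c(Cl)cncc1-c1ccc(Cl)s1)CC2` gives 560 nM, so the three stand together within the scatter. Compound 4 `O=C1NCCC12CCN(c1c(Cl)cncc1-c1ccc(CN3CCCCC3)s1)CC2` differs from compound 3 by (piperidin-1-yl)methyl in place of chloro on an aromatic carbon. The measured steps that bear on this change are exchanges of the aromatic group: a 1.3-fold lower number from compound 1 to compound 3 (0.13 log units; within the scatter), a 1.9-fold lower number from compound 2 to compound 3 (0.27 log units; within the scatter) and a 1.4-fold higher number from compound 1 to compound 2 (0.15 log units; within the scatter), each within the scatter. None of them tests a (piperidin-1-yl)methyl group, so they offer weak guidance, and no step beyond the scatter is expected in this assay. The expected step is a 1.4-fold lower number from compound 3 to compound 4 (0.15 log units; within the scatter). Compound 4 is estimated at 400 nM, with an expected range of 100 nM to 1500 nM.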

Compound 4, concentration for 50% growth inhibition: 4010 nM
Compound 4: the middle estimate sits 10-fold (1.00 log units) below what was measured, outside the stated range (above it).
By their numbers in this assay, from the lowest: compounds 3, 1 and 2 (each within the scatter of the next); then compound 4.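

In this assay, (piperidin-1-yl)methyl in place of chloro gives a 7.2-fold higher number from compound 3 to compound 4 (0.85 log units; beyond the scatter) and is the only step beyond the scatter among these compounds, since the exchanges of the aromatic group all stayed within it. Growth inhibition at this position, next to the ring sulfur, therefore depends on the group it carries. No measured evidence bears on the reason for this step.

On these data alone, whether the ring nitrogen or the size of the group matters stays open. A plain methyl group or a morpholin-4-ylmethyl group at this position would help separate the two.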